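The source may report more compounds than this note shows. Statements on the series, on what has been measured and on what is new or still open speak of the compounds shown alone.

The measured compounds stand as follows. Compound 1 `O=C1NCCc2nc(C#Cc3ccccc3F)sc21` is measured at 1500 nM. Compound 2 `CN1CCc2nc(C#Cc3cccc(F)c3)sc2C1` returns only the limit > 10000 nM. Compound 3 `C(#Cc1nc2c(s1)CN(C1CCCCC1)CC2)c1ccccc1` likewise returns only the limit > 10000 nM.

Among the compounds with values here, in an assay on HEK293 cells for positive allosteric modulation of metabotropic glutamate receptor 5 (Homo sapiens), read by FLIPR, with a stated time of 1 h (on this read-out lower numbers stand for an effect already at smaller amounts and higher numbers for an effect only at larger amounts of compound), compound 1 gives 1500 nM, the single numeric value seen so far. Compound 3 sits at the limit of > 10000 nM in this assay, at which 2 of the 3 values shown sit, so for it no number is known, only that it lies beyond that boundary. Compound 4 `O=C(C1CCCCO1)N1CCc2nc(C#Cc3ccccc3)sc2C1` is the next compound to be measured there. It differs from compound 3 in one place: (oxan-2-yl)carbonyl in place of cyclohexyl on an amine nitrogen in a ring.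

Within the data shown here, no step between measured compounds has been established, so the size of the change can only be expected. Compound 4 is expected to gain, with a step of an at least 6.6-fold lower number from compound 3 to compound 4 (0.82 log units; beyond the scatter), because compound 1, which also carries a carbonyl on the ring nitrogen, gives 1500 nM. Compound 2 and compound 3, each with an uncarbonylated amine, return no number in this assay. For compound 4 the estimate in this assay is 1500 nM, within a range from 300 nM to 8000 nM.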

Compound 4, half-maximal effective concentration: 320 nM
Beside the measured number, compound 4's estimate is 4.7-fold (0.67 log units) above it, within the range that was stated.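

In this assay, the change on the amine nitrogen in a ring gives an at least 31-fold lower number from compound 3 to compound 4 (1.49 log units; beyond the scatter). This is the first pair among the compounds shown that differs in one place, and it shows that the group on this nitrogen can by itself turn a limit into a measured number. Compound 3 remains a limit, not a number: the limit of > 10000 nM in this assay, at which 2 of the 4 values shown sit.

The carbonyl and the ring of the oxan-2-yl group enter together, and this pair does not separate them. From the compounds shown here alone, whether a cyclohexylcarbonyl group on this nitrogen would give a similar result remains open.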